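The compounds below may be only part of what the source reports. "The series", "measured", "known", "first", "only" and "open" are said of these compounds alone.

Compound 1 `COc1cccc(C(O)CCn2nc3c(Br)c(Br)c(Br)c(Br)c3n2)c1`: 106%
Compound 2 `OC(CCn1nc2c(Br)c(Br)c(Br)c(Br)c2n1)c1ccc(Br)cc1`: 109%

Of the compounds shown here, two sharing the same core have been measured in a functional assay on CCRF-CEM cells (Homo sapiens) for antiproliferative activity, read by MTT assay, with a stated time of 24 h, tested at 25 uM; on this read-out lower numbers stand for a stronger effect and higher numbers for a weaker effect at the one concentration tested. Compound 1 `COc1cccc(C(O)CCn2nc3c(Br)c(Br)c(Br)c(Br)c3n2)c1` gives 106% in this assay, and compound 2 `OC(CCn1nc2c(Br)c(Br)c(Br)c(Br)c2n1)c1ccc(Br)cc1` gives 109%. Of the two numbers shown, compound 2 stands at the top, but its only neighbour is compound 1, and the step that separates them, a number 3 percentage points higher from compound 1 to compound 2 (within the scatter), is within the scatter; the two values are thus not distinguishable.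

Compound 3 `OC(CCn1nc2c(Br)c(Br)c(Br)c(Br)c2n1)c1ccc(Cl)cc1` is not yet measured. It differs from compound 2 by chloro in place of bromo on an aromatic carbon. Going by the values given here, the one measured step that bears on this change is the exchange of the whole aryl group from compound 1 to compound 2, which gave a number 3 percentage points higher from compound 1 to compound 2 (within the scatter). That exchange was larger than the one from bromo to chloro and still produced no shift beyond the scatter, so no step beyond the scatter is expected here either, in either direction.

Compound 3 is therefore expected to give 107% in this assay, in a range from 96% to 118%, which corresponds to an expected step of a number 2 percentage points lower from compound 2 to compound 3 (within the scatter).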

Compound 3, a percentage reported as activity, at one concentration (the size of the read-out at that concentration, not a potency): 106%
Compound 3: middle estimate off by 1 percentage points, on the high side, and the stated range covers the measured number.
By their numbers in this assay, from the lowest: compounds 1, 3 and 2 (each within the scatter of the next).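

In this assay, going by these compounds alone, the exchange of bromo for chloro on the aromatic carbon para to a large group reads as a number 3 percentage points lower from compound 2 to compound 3 (within the scatter) and so gives the first direct look at this position, where the read-out does not separate the two halogens. The exchange of 3-methoxyphenyl for 4-chlorophenyl reads as no change at the digits printed from compound 1 to compound 3 (within the scatter) and is a second change of the whole aryl group that stays within the scatter, so all three compounds now lie within the scatter of one another at the one concentration tested. Nothing available here accounts for this lack of separation among the three aryl groups.

The compounds shown carry only bromo, chloro or methoxy on the phenyl ring, so it remains open whether an amine or a carboxylic acid at that ring would move the number beyond the scatter. Also open, on these data alone, is what a longer chain, or a carbonyl in place of the hydroxyl-bearing carbon, would do to the read-out on the shared core.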